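The source may report more compounds than this note shows. Statements on the series, on what has been measured and on what is new or still open speak of the compounds shown alone.

In a functional assay on ECa-109 cells for inhibition, with ECa-109 cell line (Homo sapiens) as the target, read by sulforhodamine B assay (on this read-out higher numbers stand for weaker inhibition and lower numbers for stronger inhibition), compound 1 `O=C1C(Nc2ccccc2F)=CC(=O)c2c1nc1n2[C@H]2OC[C@@H](O)[C@H]2OC1` gives 2660 nM as a measured number. Compound 2 `COc1ccccc1NC1=CC(=O)c2c(nc3n2[C@H]2OC[C@@H](O)[C@H]2OC3)C1=O` gives > 4000 nM which is a limit of the assay and not a number. The record so far holds the limit of > 4000 nM in this assay, at which 1 of the 2 values shown sits, and no number for compound 2. Compound 3 `CCOc1ccccc1NC1=CC(=O)c2c(nc3n2[C@H]2OC[C@@H](O)[C@H]2OC3)C1=O` differs from compound 2 by methyl in place of hydrogen on a saturated chain carbon bound to an oxygen on an aromatic ring in the change from methoxy to ethoxy, or 2-methoxyphenyl to 2-ethoxyphenyl. Going by the values given here, the only measured step that bears on this is an at least 1.5-fold higher number from compound 1 to compound 2 (0.17 log units; that floor lies within the scatter) with methoxy in place of fluoro on an aromatic carbon. That is a different change, and it gives no direction for methoxy to ethoxy. No step beyond the scatter is therefore expected in this assay in either direction. The expected step is a step that the limit leaves unreadable from compound 2 to compound 3 on this estimate. Compound 3 is estimated at 4500 nM with an expected range of 2200 nM to 9000 nM. It may well be expected to reach only a limit of the assay.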

Compound 3, half-maximal inhibitory concentration: 4320 nM
Compound 3: the middle estimate sits 1.0-fold (0.02 log units) above what was measured; low and high end bracket the measured number.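

Compound 2, at > 4000 nM, holds a limit of the assay and not a number. The step from methoxy to ethoxy cannot be read, because compound 2 carries that limit: the limit of > 4000 nM in this assay, at which 1 of the 3 values shown sits. What the new result adds is a second measured number for this place on the 2-substituted phenyl group: in this assay, replacing fluoro with ethoxy gives a 1.6-fold higher number from compound 1 to compound 3 (0.21 log units; within the scatter), so these two groups are not separated by this read-out, and an alkoxy group at this place is compatible with a measured number.

The compounds shown leave open whether methoxy and ethoxy differ at all, since only fluoro and ethoxy can be compared as numbers, and two measured values give no trend across this place. From the compounds shown here alone, it also remains open whether a longer chain such as propoxy, an amine or a carboxylic acid on this aromatic carbon would give a step beyond the scatter in either direction from the values of compound 1 and compound 3.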